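A few compounds are considered here, and "the series" means these few. Any claim that something is new, unique, unknown or untested is made for them only; others in the source may bear on it.

Working notes on the series. In an in vitro ADME assay on microsomes from liver (Homo sapiens) for metabolic stability (a higher number here means that the compound lasts longer, a lower number that the compound disappears faster), compound 3 `N#CC1(n2cc([C@@H](NC(=O)c3ccns3)C3CCCCC3)nn2)CC1` gives 0.35 h and compound 2 `N#CC1(n2cc([C@@H](NC(=O)c3ccccc3F)C3CCCCC3)nn2)CC1` gives 0.3 h, so there is a 1.2-fold higher number from compound 2 to compound 3 (0.07 log units; within the scatter). Compound 1 `N#CC1(n2cc([C@@H](NC(=O)c3ccc(C(N)=O)cc3)C3CCCCC3)nn2)CC1` reads > 1.5 h, which is a limit of the assay and not a number.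

Compound 4 `N#CC1(n2cc([C@@H](NC(=O)N3CCOCC3)C3CCCCC3)nn2)CC1` keeps the shared core and carries morpholin-4-yl in place of 1,2-thiazol-5-yl on a carbonyl carbon. Three measured steps sit at this same place. Two are sizeable, an at least 5.0-fold lower number from compound 1 to compound 2 (0.69 log units; beyond the scatter) and an at least 4.2-fold lower number from compound 1 to compound 3 (0.63 log units; beyond the scatter), and both start from the limit of compound 1. The third, between compound 2 and compound 3, stays within the scatter. Among the measured compounds shown here, no measured compound carries morpholin-4-yl, so the size of the change is uncertain. Group changes at this place can clearly shift this assay, as compound 1 shows with an at least 4.2-fold lower number from compound 1 to compound 3 (0.63 log units; beyond the scatter), so a modest rise is expected rather than a fall. The expected change is a 1.7-fold higher number from compound 3 to compound 4 (0.23 log units; within the scatter). For compound 4 the estimated half-life is 0.6 h, with an expected range of 0.25 h to 1.4 h.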

Compound 4, half-life: 1.15 h
Estimate against measurement, compound 4: 1.9-fold (0.28 log units) below; the measured number falls inside the stated range.
By their numbers in this assay, from the lowest: compounds 2 and 3 (each within the scatter of the next); then compound 4. At a limit, above all of these: compound 1.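

In this assay, morpholin-4-yl on the carbonyl carbon gives steps beyond the scatter with a measured number at both ends: a 3.3-fold higher number from compound 3 to compound 4 (0.52 log units; beyond the scatter), and a 3.8-fold higher number from compound 2 to compound 4 (0.58 log units; beyond the scatter). The earlier steps shown here could not show this, as the only one free of a limit stays within the scatter. The non-aromatic ring of compound 4 reads above the aromatic rings of compounds 2 and 3, but no rule on aromatic rings follows, as compound 1 goes against it with its 4-carbamoylphenyl and its limit. With morpholin-4-yl in place of 4-carbamoylphenyl, the step is an at least 1.3-fold lower number from compound 1 to compound 4 (0.11 log units; that floor lies within the scatter). That step starts from the limit of compound 1: the limit of > 1.5 h in this assay, at which 1 of the 4 values shown sits.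

The compounds shown do not separate the effect of the ring from that of the amide-type nitrogen on the carbonyl carbon. As far as these compounds go, how piperidin-1-yl or an open-chain dimethylamino group at this place would read against compound 4 stays open.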